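Bromo for Chloro in Hydrazone Cytotoxicity on HEL Cells

A few compounds are considered here, and "the series" means these few. Any claim that something is new, unique, unknown or untested is made for them only; others in the source may bear on it.

Compound 1 `O=C(N/N=C/c1cccc(Cl)c1)c1cccnc1`: > 100 ug/mL
Compound 2 `O=C(N/N=C/c1ccc(Cl)cc1)c1cccnc1`: > 100 ug/mL
Compound 3 `O=C(N/N=C/c1cccc(Br)c1)c1cccnc1`: > 100 ug/mL

In an ADME assay on HEL cells (Homo sapiens) for cytotoxicity, read by microscopy (a lower number here means that less compound is tolerated, a higher number that more compound is tolerated), compound 1 gives only a limit, > 100 ug/mL. Compound 3 likewise gives only a limit, > 100 ug/mL. The change between them, (bromo in place of chloro on an aromatic carbon), therefore yields a step that the two limits leave unreadable from compound 1 to compound 3. Compound 2 also gives only a limit, > 100 ug/mL; the difference between the cores of compound 1 and compound 2 is not broken down here.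

Compound 4 `O=C(N/N=C/c1ccc(Br)cc1)c1cccnc1` is not yet measured. It differs from compound 2 by bromo in place of chloro on an aromatic carbon, the same kind of change as from compound 1 to compound 3, though there the bromo sits meta to a large group and here para to a large group. Because (the limit of > 100 ug/mL in this assay, at which 3 of the 3 values shown sit), compound 4 is expected to show a step of a number no higher from compound 2 to compound 4 (the limit leaves the size open) in this assay. Compound 4 is accordingly estimated at 100 ug/mL, within 50 ug/mL to 200 ug/mL.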

Compound 4, minimum cytotoxic concentration: > 100 ug/mL
Compound 4 ended at the assay's limit; the forecaster's own chance of this, stated with the estimate: 85%; the middle value lies on the limit itself.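

Compound 2 and compound 4 each give only a limit in this assay, so the step between them cannot be read. The compounds shown leave open whether bromo and chloro differ in this read-out at all: the limit of > 100 ug/mL in this assay, at which 4 of the 4 values shown sit.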